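Pentyloxy chain in place of the ester end

A few compounds are considered here, and "the series" means these few. Any claim that something is new, unique, unknown or untested is made for them only; others in the source may bear on it.

In a functional assay on HL-60 cells (Homo sapiens) for antiproliferative activity (a lower number here means a stronger inhibitor of growth, a higher number a weaker inhibitor of growth), compound 1 `COCCCCCCCCCCCCCCC/C=C1/CC(CO)(COC(=O)C(C)(C)C)OC1=O` gives 3.97 ug/mL and compound 2 `COCCCCCCCCCCC/C=C1\CC(CO)(COC(=O)C(C)(C)C)OC1=O` gives 5.22 ug/mL with the two values within the usual scatter of each other. Compound 3 `COC(=O)CCCCCCCCCCCCCC/C=C1\CC(CO)(COC(=O)C(C)(C)C)OC1=O` reads > 10 ug/mL, which is a limit and not a number (the limit of > 10 ug/mL in this assay, at which 1 of the 3 values shown sits).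

Compound 4 `CCCCCOCCCCCCC/C=C1\CC(CO)(COC(=O)C(C)(C)C)OC1=O` differs from compound 3 by one change: pentyloxy in place of 7-(methoxycarbonyl)heptyl on a saturated chain carbon, seven bonds along the chain from a double-bonded chain carbon. In words, this is pentyloxy in place of 7-(methoxycarbonyl)heptyl on a saturated chain carbon, seven bonds along the chain from a double-bonded chain carbon. The methoxycarbonyl end is lost, and the chain carries an alkoxy group, as in compounds 1 and 2.

Among the compounds with values here, only one measured step bears on this: an at least 1.9-fold higher number from compound 2 to compound 3 (0.28 log units; that floor lies within the scatter), with 3-(methoxycarbonyl)propyl in place of methoxy. That step brought in the methoxycarbonyl end, whereas the present change removes it, so a modest move to a lower number in this assay is expected, towards the values of compounds 1 and 2. The support is thin, since that step is known only as a floor. The expected step is an at least 1.6-fold lower number from compound 3 to compound 4 (0.22 log units; that floor lies within the scatter). Compound 4 is expected at 6 ug/mL, with an estimated range of 3 ug/mL to 10 ug/mL.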

Compound 4, concentration for 50% growth inhibition: 2.96 ug/mL
Beside the measured number, compound 4's estimate is 2.0-fold (0.31 log units) above it; measured number below the stated range.
By their numbers in this assay, from the lowest: compounds 4, 1 and 2 (each within the scatter of the next). At a limit, above all of these: compound 3.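

In this assay, within the data shown here, the change from 7-(methoxycarbonyl)heptyl to pentyloxy gives the first step that lies beyond the scatter: an at least 3.3-fold lower number from compound 3 to compound 4 (0.52 log units; beyond the scatter). Compound 3 stands at a limit and not at a number, so this step is known only as a floor: the limit of > 10 ug/mL in this assay, at which 1 of the 4 values shown sits. With a 1.8-fold lower number from compound 2 to compound 4 (0.25 log units; within the scatter), pentyloxy in compound 4 and 4-methoxybutyl in compound 2 cannot be told apart at this position, so a chain without the methoxycarbonyl end reads in the same range whether its alkoxy group is pentyloxy or methoxy.

In the step from compound 3, the methoxycarbonyl end and the chain length change together, and the compounds shown do not separate the two. Also open, on these data alone, is how a carboxylic acid or an amine at the chain end, or a longer alkoxy chain such as decyloxy, would read on saturated chain carbon seven bonds along the chain from the double-bonded chain carbon.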